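Swapping methoxy for nitro: an expected rise in inhibition

The source may report more compounds than this note shows. Statements on the series, on what has been measured and on what is new or still open speak of the compounds shown alone.

In a functional assay on HO8910 cells (Homo sapiens) for inhibition, read by MTT assay, with a stated time of 24 h, tested at 100 ug/mL (on this read-out higher numbers stand for more inhibition of growth at the one concentration tested and lower numbers for less inhibition of growth), compound 1 `O=C(CCCCC(S)CCS)Nc1ccc(OC(F)(F)F)cc1` gives 66.8% while compound 2 `COc1ccc(NC(=O)CCCCC(S)CCS)cc1` gives 12.6% and so stands lowest of the two. Compound 3 `O=C(CCCCC(S)CCS)Nc1ccc([N+](=O)[O-])cc1` has not been measured yet. It carries nitro in place of methoxy on an aromatic carbon, para to a large group (nitro in place of methoxy on an aromatic carbon). For the measured compounds named here, only one measured step bears on this change: a number 54.2 percentage points lower from compound 1 to compound 2 (beyond the scatter) for methyl in place of trifluoromethyl on an oxygen on an aromatic ring, and it is large. Going by the values given here, no nitro compound has been measured, so that step shows only that one change of group can move this number far. Compound 2 with its 12.6% has little room to fall, so an upward move is expected. The estimated step is a number 27.4 percentage points higher from compound 2 to compound 3 (beyond the scatter) in size, resting on thin evidence. For compound 3 the estimated value is 40% with 15% to 70% as the expected range.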

Compound 3, percent growth inhibition at one concentration: 51.2%
Compound 3: middle estimate off by 11.2 percentage points, on the low side; the range from low to high includes it.
By their numbers in this assay, from the lowest: compound 2; then compound 3; then compound 1.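

On this assay, the aromatic carbon para to a large group now shows a second large change: nitro in place of methoxy gives a number 38.6 percentage points higher from compound 2 to compound 3 (beyond the scatter). Trifluoromethoxy is therefore not the only group here that stands well above methoxy, although nitro does not match it, with a number 15.6 percentage points lower from compound 1 to compound 3 (beyond the scatter). Among these three groups, methoxy sits at the low end and each pair is separated beyond the scatter, so this position tells the three groups apart clearly.

Nothing available here explains why these groups differ in this way. As far as these compounds go, it remains open whether an amine, a carboxylic acid or a single chlorine atom at this place would fall nearer compound 2 or compound 1, and whether the same order would hold at other concentrations.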